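Hydroxy for chloro on the pyrimidine of compound 2

This account rests on a few compounds, and the source may have more. Where it says the series, first, only, none or still open, it means among the compounds named here.

Measured so far:
Compound 1, `Cc1cnc(N2CCC(c3coc4c(N5CCc6cc(S(C)(=O)=O)ccc65)ncnc34)CC2)nc1`, 159%
Compound 2, `CS(=O)(=O)c1ccc2c(c1)CCN2c1ncnc2c(C3CCN(c4ncc(Cl)cn4)CC3)coc12`, 117%

Within the data shown here, in a functional assay on cells for agonist activity at Glucose-dependent insulinotropic receptor (Homo sapiens), read by a luciferase reporter, with a stated time of 4 h (a higher number here means a larger maximal response, a lower number a smaller maximal response), compound 2 stands lowest of the two numbers measured; its nearest neighbour is compound 1, and the one measured step, a number 42 percentage points lower from compound 1 to compound 2 (beyond the scatter), separates them. Compound 3, `CS(=O)(=O)c1ccc2c(c1)CCN2c1ncnc2c(C3CCN(c4ncc(O)cn4)CC3)coc12`, differs from compound 2 in one place: hydroxy in place of chloro on an aromatic carbon. Among the measured compounds shown here, no measured step exchanges chloro for hydroxy, so the only step that bears on it, a number 42 percentage points lower from compound 1 to compound 2 (beyond the scatter), is of another kind and shows merely that a change at this aromatic carbon can shift the maximal response strongly. With so little to go on, compound 3 is expected to stay near compound 2, with the step of a number 7 percentage points lower from compound 2 to compound 3 (within the scatter) set small and its range left wide in both directions. The estimated maximal response of compound 3 in this assay is 110%, between 70% and 150%.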

Compound 3, largest response reached (Emax), in percent of the reference or control that the assay uses: 145%
For compound 3 the middle estimate is 35 percentage points below the measured one, within the range that was stated.
By their numbers in this assay, from the lowest: compound 2; then compound 3; then compound 1.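

In this assay, among these compounds, the change from 5-chloropyrimidin-2-yl to 5-hydroxypyrimidin-2-yl gives a number 28 percentage points higher from compound 2 to compound 3 (beyond the scatter) on this aromatic carbon, so the earlier drop with chloro is not the only direction a change here can take. Hydroxy does not fully match methyl, with a number 14 percentage points lower from compound 1 to compound 3 (beyond the scatter) in the same read-out, and the three groups now fall in the order chloro, hydroxy, methyl, from the smallest maximal response to the largest. Nothing available explains this order.

The compounds shown leave open where a methoxy group, an amine or a carboxylic acid on this carbon would fall in that order. They also leave open whether the hydrogen-bond donor that enters with hydroxy matters, and whether any group here exceeds methyl.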